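Dihydroxyphenyl exchange: from compound 3 to compound 4

The source may hold more compounds than are shown below. What is called first, only, known or untested is meant among the compounds shown, and "the series" means these compounds.

Measured in a functional assay, with a stated time of 30 min; a lower number here means a stronger inhibitor, a higher number a weaker inhibitor:
- Compound 1 `O=C(/C=C/c1ccc(O)c(O)c1)CC(=O)/C=C/c1cccc(O)c1O`: 19000 nM
- Compound 2 `O=C(/C=C/c1cccc(O)c1O)CC(=O)/C=C/c1cccc(O)c1O`: 30000 nM
- Compound 3 `O=C(/C=C/c1cc(O)ccc1O)CC(=O)/C=C/c1cccc(O)c1O`: 27000 nM
- Compound 4 `O=C(/C=C/c1cc(O)ccc1O)CC(=O)/C=C/c1cc(O)ccc1O`: not yet measured

The three measured values lie close together, and compound 3 has no distinct place among them: a 1.4-fold higher number from compound 1 to compound 3 (0.15 log units; within the scatter), and a 1.1-fold lower number from compound 2 to compound 3 (0.05 log units; within the scatter). Neither step leaves the usual scatter of the read-out, so the three compounds cannot be ranked.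

The next step is a single exchange: 2,5-dihydroxyphenyl in place of 2,3-dihydroxyphenyl on a double-bonded chain carbon bound to a double-bonded chain carbon. Compound 4 then carries 2,5-dihydroxyphenyl in both places where the series varies this group. The same exchange has been measured once, and that step is the closest guide: a 1.1-fold lower number from compound 2 to compound 3 (0.05 log units; within the scatter). The other exchanges of a dihydroxyphenyl pattern at this place are also small: a 1.6-fold higher number from compound 1 to compound 2 (0.20 log units; within the scatter), and a 1.4-fold higher number from compound 1 to compound 3 (0.15 log units; within the scatter). For the measured compounds named here, no measured step in this small set exceeds the scatter, so no step beyond the scatter is expected in this assay, and no direction can be assigned. The expected step is no change at the digits printed from compound 3 to compound 4 (within the scatter). For compound 4 the estimated value is 27000 nM, with an expected range from 13000 nM to 50000 nM.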

Compound 4, half-maximal inhibitory concentration: 57000 nM
Compound 4: the middle estimate sits 2.1-fold (0.32 log units) below what was measured; measured number outside the range, above it.
By their numbers in this assay, from the lowest: compounds 1, 3, 2 and 4 (each within the scatter of the next, the first and the last beyond it).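

In this assay, for the compounds shown here, the exchange of 2,3-dihydroxyphenyl for 2,5-dihydroxyphenyl gives the first step in this set that leaves the scatter: a 2.1-fold higher number from compound 3 to compound 4 (0.32 log units; beyond the scatter). The earlier compounds shown here gave no sign that the hydroxyl pattern on this group could register at all, and the same exchange in the other measured instance stays within the scatter: a 1.1-fold lower number from compound 2 to compound 3 (0.05 log units; within the scatter). The exchange therefore has no single reading across these two pairs, as its step is modest in one and unresolved in the other, and nothing available bears on the reason for this.

The compounds shown leave open whether the step belongs to the 2,5-dihydroxyphenyl pattern itself or appears only when that group already stands in the other place where the series varies, as it does in compound 3. They also leave open how far a hydroxyl is needed on these rings at all, which a methoxy group or a carboxylic acid in place of a hydroxyl would address, and whether any such change would produce a step larger than this one.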